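Swapping a difluorophenyl for a bromophenyl on a weak inhibitor

The source may hold more compounds than are shown below. What is called first, only, known or untested is meant among the compounds shown, and "the series" means these compounds.

Compound 1 `Cc1nn(C)c(Oc2ccc(Br)cc2)c1/C=N\CCCCCOc1cc2oc(=O)cc(C)c2cc1Cl`: 13800 nM
Compound 2 `Cc1nn(C)c(Oc2cccc(F)c2F)c1/C=N\CCCCCCOc1cc2oc(=O)cc(C)c2cc1Cl`: > 25000 nM

These two compounds were tested in a functional assay on HepG2 cells (Homo sapiens) for antiproliferative activity, read by MTT assay, with a stated time of 72 h; a higher number here means a weaker inhibitor, a lower number a stronger inhibitor. Compound 1 gives 13800 nM in this assay. Compound 2 reaches only > 25000 nM, which is a limit of the assay and not a number; this is the limit of > 25000 nM in this assay, at which 1 of the 2 values shown sits. Compound 2 therefore stands at the weak end of what this assay can report, while compound 1 sits inside the measurable range.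

Compound 3 `Cc1nn(C)c(Oc2cccc(Br)c2)c1/C=N\CCCCCCOc1cc2oc(=O)cc(C)c2cc1Cl` has not yet been measured. It differs from compound 2 in one place: 3-bromophenyl in place of 2,3-difluorophenyl on an oxygen on an aromatic ring. Because compound 2 sits at the limit (the limit of > 25000 nM in this assay, at which 1 of the 2 values shown sits), the size of this step can only be guessed. For compound 3 a modest step toward stronger inhibition is expected, an at least 1.3-fold lower number from compound 2 to compound 3 (0.14 log units; that floor lies within the scatter), not clearly beyond the scatter. Compound 3 is estimated at 18000 nM, within a range from 7000 nM to 45000 nM.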

Compound 3, half-maximal inhibitory concentration: 6830 nM
For compound 3 the middle estimate is 2.6-fold (0.42 log units) above the measured one; the measured number lies below the stated range.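

On an oxygen on an aromatic ring, 3-bromophenyl in place of 2,3-difluorophenyl brings the series from the assay limit into the measurable range: in this assay the change gives an at least 3.6-fold lower number from compound 2 to compound 3 (0.56 log units; beyond the scatter). This is the only single-place comparison among the compounds shown, and it shows that this position can change antiproliferative activity by more than the usual scatter. The true size of the step remains unknown, and only its minimum can be stated, because one end of it rests on a limit: the limit of > 25000 nM in this assay, at which 1 of the 3 values shown sits.

The change removes two fluorines and adds one bromine together, which leaves unresolved which of these matters. Also open, as far as these compounds go, is how this position would respond to 3-chlorophenyl, or to a phenyl ring carrying an amine or a carboxylic acid.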